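A few compounds are considered here, and "the series" means these few. Any claim that something is new, unique, unknown or untested is made for them only; others in the source may bear on it.

Compound 2 `Nc1nc(OCc2ccccc2)c2ncn(/C=C3/CC3(CO)CO)c2n1` was tested in an ADME assay on CCRF-HSB-2 cells (Homo sapiens) for cytotoxicity, with a stated time of 7 days (on this read-out higher numbers stand for lower toxicity in this test and lower numbers for higher toxicity in this test), where compound 2 gives only the assay's limit, > 20000 nM. Compound 1 `Nc1nc(OCC(F)(F)F)c2ncn(/C=C3/CC3(CO)CO)c2n1` likewise gives only a limit, > 20000 nM. Between them the step that the two limits leave unreadable from compound 1 to compound 2 cannot be sized because both values sit at the limit (the limit of > 20000 nM in this assay, at which 2 of the 2 values shown sit). Compound 3 `CCCCCCCCSc1nc(N)nc2c1ncn2/C=C1/CC1(CO)CO` differs from compound 2 by octylsulfanyl in place of benzyloxy on an aromatic carbon. Going by the values given here, no measured step bears on this change, and both values shown are limits, so no readable step is expected in this assay. Compound 3 is therefore estimated at 20000 nM, within 8000 nM to 50000 nM, meaning an expected step of a number no higher from compound 2 to compound 3 (the limit leaves the size open).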

Compound 3, half-maximal cytotoxic concentration: 60000 nM
For compound 3 the middle estimate is 3.0-fold (0.48 log units) below the measured one, and the stated range ends below it.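

No step from compound 1 or compound 2 to compound 3 can be sized, because the values of compound 1 and compound 2 are limits: the limit of > 20000 nM in this assay, at which 2 of the 3 values shown sit.

On these data alone, whether octylsulfanyl changes cytotoxicity compared with benzyloxy or 2,2,2-trifluoroethoxy stays open.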